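This account rests on a few compounds, and the source may have more. Where it says the series, first, only, none or still open, it means among the compounds named here.

Compound 2 `CN(Cc1nc2cccc(CCCN3CCCCC3)c2[nH]1)C1CCCc2cccnc21` was tested in an ADME assay on HOS cells (Homo sapiens) for cytotoxicity (on this read-out higher numbers stand for lower toxicity in this test and lower numbers for higher toxicity in this test), where compound 2 gives 8700 nM. Compound 1 `CN(Cc1nc2cccc(CCCN)c2[nH]1)C1CCCc2cccnc21` differs from it in one place, and in this assay compound 1 gives 10000 nM; the two numbers sit within the scatter of each other, as the step of a 1.1-fold lower number from compound 1 to compound 2 (0.06 log units; within the scatter) shows, so neither can be called gentler or harsher on the cells than the other.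

Compound 3 `CN(Cc1nc2cccc(N3CCNCC3)c2[nH]1)C1CCCc2cccnc21` is the next step from compound 2: piperazin-1-yl in place of 3-(piperidin-1-yl)propyl on an aromatic carbon. Among the measured compounds shown here, the only measured step, from an amino to a piperidin-1-yl end of the chain, changed nothing beyond the scatter, and no measured pair shows the exchange of the whole chain for a ring set directly on the aromatic carbon. With that thin basis, compound 3 is expected to stay near compound 2, giving an estimated 1.1-fold higher number from compound 2 to compound 3 (0.06 log units; within the scatter) in this assay. The estimate for compound 3 is therefore 10000 nM, within a range from 4000 nM to 25000 nM.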

Compound 3, half-maximal cytotoxic concentration: > 20000 nM
Compound 3 gave a limit, no number; the forecaster's own chance of this, stated with the estimate: 30%; middle value at least 2.0-fold (0.30 log units) away from the limit.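

In this assay compound 3 gives only a limit, not a number: the limit of > 20000 nM in this assay, at which 1 of the 3 values shown sits. Even so, setting piperazin-1-yl directly on the aromatic carbon in place of the 3-(piperidin-1-yl)propyl chain gives an at least 2.2-fold higher number from compound 2 to compound 3 (0.36 log units; beyond the scatter), so a change at this position can move the read-out beyond the scatter, which changing only the end of the chain did not do. Against the 3-aminopropyl chain, the step is an at least 2.0-fold higher number from compound 1 to compound 3 (0.30 log units; that floor lies within the scatter), so that comparison stays unsettled.

The change removes the chain and alters the ring at once, so the compounds shown do not tell which of the two matters. Piperazin-1-yl at the end of a propyl chain, or a morpholin-4-yl ring set directly on the aromatic carbon, would help separate the two.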